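The compounds below may be only part of what the source reports. "The series", "measured", "known", "first", "only" and "open" are said of these compounds alone.

Among the compounds with values here, in a functional assay on KB cells (Homo sapiens) for cytotoxicity, read by MTT assay, with a stated time of 3 days (a lower number here means a stronger inhibitor, a higher number a weaker inhibitor), three compounds built on a shared core have numbers so far. Compound 1 `CNc1nc(SCc2nc3ccccc3[nH]2)nc(-c2ccccc2)c1C#N` gives 2.7 nM, compound 2 `CCNc1nc(SCc2nc3ccccc3[nH]2)nc(-c2ccccc2)c1C#N` gives 7.35 nM, and compound 3 `N#Cc1c(NC(N)=S)nc(SCc2nc3ccccc3[nH]2)nc1-c1ccccc1` gives 3.2 nM. Two steps place compound 3: a 1.2-fold higher number from compound 1 to compound 3 (0.07 log units; within the scatter), and a 2.3-fold lower number from compound 2 to compound 3 (0.36 log units; beyond the scatter). It therefore sits level with compound 1, and the pair stands apart from compound 2.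

Compound 4 `N#Cc1c(NC(N)=O)nc(SCc2nc3ccccc3[nH]2)nc1-c1ccccc1` has not yet been measured. It carries a carbamoyl group on a nitrogen on an aromatic ring, and the change is a group of 3 heavy atoms (1 carbon, 1 nitrogen, 1 oxygen; no ring) in place of a group of 3 heavy atoms (1 carbon, 1 nitrogen, 1 sulfur; no ring), on a nitrogen on an aromatic ring. Within the data shown here, no measured step makes this exact exchange. Still, all three measured steps alter the group on that nitrogen, and even the largest, a 2.7-fold higher number from compound 1 to compound 2 (0.43 log units; beyond the scatter), is only modest. The exchange also keeps the counted donors and acceptors unchanged, so no large shift is expected in this assay. The expected step is a 1.3-fold higher number from compound 3 to compound 4 (0.10 log units; within the scatter), with no firm direction and nothing expected beyond the scatter. Compound 4 is estimated at 4 nM, with an expected range from 1.5 nM to 11 nM.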

Compound 4, half-maximal inhibitory concentration: 9.6 nM
Compound 4: middle estimate off by 2.4-fold (0.38 log units), on the low side; low and high end bracket the measured number.
By their numbers in this assay, from the lowest: compounds 1 and 3 (each within the scatter of the next); then compounds 2 and 4 (each within the scatter of the next).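

In this assay, within the data shown here, the exchange of the sulfur-bearing group for carbamoyl gives a 3.0-fold higher number from compound 3 to compound 4 (0.48 log units; beyond the scatter) even though the counted donors and acceptors stay the same, so this position on the nitrogen responds to a change of that one atom, which the earlier steps could not show. Carbamoyl does not separate from ethyl, with a 1.3-fold higher number from compound 2 to compound 4 (0.12 log units; within the scatter) as the comparison, but it stands apart from methyl, with a 3.6-fold higher number from compound 1 to compound 4 (0.55 log units; beyond the scatter) as the widest step yet seen on this nitrogen. Nothing measured here explains why the exchange shifts the number.

From the compounds shown here alone, what remains open is how a plain amine, an acetyl group or a longer chain such as propyl would behave on this nitrogen. Going by these compounds, it is also open whether the gap between the thiourea-type group and carbamoyl would hold in other cell lines.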